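This account rests on a few compounds, and the source may have more. Where it says the series, first, only, none or still open, it means among the compounds named here.

Measured compounds:
- compound 1, `CCCCCCCCn1cc(COC2(C(F)(F)F)Oc3ccccc3C=C2C(=O)OCC)nn1`: > 150000 nM
- compound 2, `CCOC(=O)C1=Cc2ccccc2OC1(OCc1cc(-c2ccc(Br)cc2)no1)C(F)(F)F`: > 150000 nM
- compound 3, `CCOC(=O)C1=Cc2ccccc2OC1(OCc1cc(-c2cccc(C(F)(F)F)c2)no1)C(F)(F)F`: 48600 nM

In a functional assay on A549 cells (Homo sapiens) for inhibition, read by MTT assay, with a stated time of 24 h (on this read-out lower numbers stand for stronger inhibition and higher numbers for weaker inhibition), compound 1 gives > 150000 nM, which is a limit of the assay and not a number. Compound 1 thus sits at the limit of > 150000 nM in this assay, at which 2 of the 3 values shown sit, so its own potency is not resolved beyond that boundary. Compound 2 also gives only a limit in this assay, > 150000 nM. Going by the values given here, compound 3 is the only compound with a resolved number, 48600 nM, and the single measured step, an at least 3.0-fold lower number from compound 2 to compound 3 (0.48 log units; beyond the scatter), is the only change in this set that moves the read-out beyond the scatter.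

The unmeasured compound 4, `CCOC(=O)C1=Cc2ccccc2OC1(OCc1cn(CC(=O)Nc2cccc(F)c2)nn1)C(F)(F)F`, differs from compound 1 by (3-fluorophenyl)carbamoyl in place of heptyl on a saturated chain carbon bound to an aromatic nitrogen. Among the compounds with values here, this change sits on the chain attached to the triazole-type part of the core of compound 1, a different region from the one altered in the step from compound 2 to compound 3, so no measured step bears directly on it. With compound 1 unresolved at the limit, the direction of any step from compound 1 to compound 4 in this assay cannot be anchored, and a value near the limit remains plausible. Compound 4 is expected to give about 120000 nM, spanning 30000 nM to 500000 nM, meaning an expected step of an at least 1.2-fold lower number from compound 1 to compound 4 (0.09 log units; that floor lies within the scatter).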

Compound 4, half-maximal inhibitory concentration: > 150000 nM
Compound 4: only a limit was reported; the forecaster's own chance of this, stated with the estimate: 55%; at least 1.2-fold (0.09 log units) between middle value and limit.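

In this assay compound 4 gives > 150000 nM, which is a limit of the assay and not a number. Going by these compounds alone, compound 1 also stands only at a limit, so no step between compound 1 and compound 4 can be read: the limit of > 150000 nM in this assay, at which 3 of the 4 values shown sit. The compounds shown leave open whether (3-fluorophenyl)carbamoyl or heptyl at this place gives stronger inhibition in this assay.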